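The source may report more compounds than this note shows. Statements on the series, on what has been measured and on what is new or still open speak of the compounds shown alone.

Measured compounds in a functional assay on HEK293 cells for antagonist activity at Voltage-dependent L-type calcium channel subunit alpha-1C (Oryctolagus cuniculus), read by FLIPR; on this read-out higher numbers stand for weaker inhibition and lower numbers for stronger inhibition:
- compound 1, `CCCC1=C(C(=O)OCC)C(c2cccc([N+](=O)[O-])c2)C(C(=O)OCC)=C(C)N1`: 18 nM
- compound 2, `CCCCC1=C(C(=O)OCC)C(c2cccc([N+](=O)[O-])c2)C(C(=O)OCC)=C(C)N1`: 20 nM
- compound 3, `CCOC(=O)C1=C(C)NC(COC(=O)c2ccccc2)=C(C(=O)OCC)C1c1cccc([N+](=O)[O-])c1`: 210 nM

Compound 3 gives the highest number of the three in this assay. Its nearest neighbour is compound 2, with an 11-fold higher number from compound 2 to compound 3 (1.02 log units; beyond the scatter); compound 1 lies furthest, with a 12-fold higher number from compound 1 to compound 3 (1.07 log units; beyond the scatter). Both steps are large and beyond the scatter, and both concern the same place, a saturated chain carbon bound to a double-bonded ring carbon, where an alkyl chain is exchanged for benzoyloxy. Compounds 1 and 2 differ from each other only by a methyl on a saturated chain carbon, and a 1.1-fold higher number from compound 1 to compound 2 (0.05 log units; within the scatter) lies within the scatter.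

Compound 4, `CCOC(=O)C1=C(C)NC(CN2CCN(c3ccccc3)CC2)=C(C(=O)OCC)C1c1cccc([N+](=O)[O-])c1`, has not been measured. It differs from compound 3 by 4-phenylpiperazin-1-yl in place of benzoyloxy on a saturated chain carbon bound to a double-bonded ring carbon. Within the data shown here, no measured step covers this exchange: the two known steps at this place go from an alkyl chain to benzoyloxy, not from benzoyloxy to another group of comparable size. Compound 4 is therefore expected to stay near compound 3 rather than return to the range of compounds 1 and 2, with a 1.4-fold lower number from compound 3 to compound 4 (0.15 log units; within the scatter) as the estimated step and wide uncertainty. Compound 4 is estimated at 150 nM, in the range 30 nM to 800 nM.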

Compound 4, half-maximal inhibitory concentration: 630 nM
Estimate against measurement, compound 4: 4.2-fold (0.62 log units) below; the measured number falls inside the stated range.
By their numbers in this assay, from the lowest: compounds 1 and 2 (each within the scatter of the next); then compound 3; then compound 4.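

In this assay, the place on a saturated chain carbon bound to a double-bonded ring carbon now separates two groups that each carry a six-membered aromatic ring of carbon only: a 3.0-fold higher number from compound 3 to compound 4 (0.48 log units; beyond the scatter) is a modest step but beyond the scatter, so the effect here is not settled by the move away from an alkyl chain alone. Against the alkyl groups the gap is wider, with a 32-fold higher number from compound 2 to compound 4 (1.50 log units; beyond the scatter) on the exchange for propyl and a 35-fold higher number from compound 1 to compound 4 (1.54 log units; beyond the scatter) on the exchange for ethyl, and 4-phenylpiperazin-1-yl gives the highest number of the groups seen at this place. Nothing on hand explains this order.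

The compounds shown leave open whether the higher numbers follow the phenyl ring, the piperazine ring or the link to the chain carbon, and plain piperazin-1-yl or a small amine such as dimethylamino at this place would help to separate these. They also leave open how far alkyl chains are tolerated here, since a longer chain such as hexyl would show whether the flat stretch from ethyl to propyl continues.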